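Removing the nitrile from compound 1

This account rests on a few compounds, and the source may have more. Where it says the series, first, only, none or still open, it means among the compounds named here.

Compound 1 `CCOc1ccc(Br)cc1-c1cc(Nc2cccc(C#N)c2)nc(N)n1`: > 1000 nM (a limit)
Compound 2 `CCOc1ccc(Cl)cc1-c1cc(Nc2ccc([N+](=O)[O-])cc2)nc(N)n1`: 350 nM

In a functional assay on DU-145 cells (Homo sapiens) for inhibition (a lower number here means a stronger inhibitor, a higher number a weaker inhibitor), compound 1 gives > 1000 nM, which is a limit of the assay and not a number. Its true position is therefore open on one side. Compound 2 gives 350 nM in this assay.

Compound 3 `CCOc1ccc(Br)cc1-c1cc(Nc2ccccc2)nc(N)n1` has not yet been measured. It keeps the core of compound 1 but has hydrogen in place of cyano on an aromatic carbon, meta to a large group, taking 3-cyanophenyl to phenyl: hydrogen in place of cyano on an aromatic carbon. Going by the values given here, no measured pair shows this change on its own, so only a modest shift is anticipated. The expected step is a step that the limit leaves unreadable from compound 1 to compound 3, not beyond the scatter. For compound 3 the estimated value is 1300 nM, with an expected range of 400 nM to 4000 nM.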

Compound 3, half-maximal inhibitory concentration: > 1000 nM
Compound 3: no number, only a limit; the forecaster's own chance of this, stated with the estimate: 45%; the middle value is on the limit's open side.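

In this assay compound 3 gives > 1000 nM as a limit and not a number. Going by these compounds alone, no step from compound 1 to compound 3 can be read, because both compounds sit at the same limit: the limit of > 1000 nM in this assay, at which 2 of the 3 values shown sit. The compounds shown leave open whether going from 3-cyanophenyl to phenyl changes inhibition at all.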